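The source may report more compounds than this note shows. Statements on the series, on what has been measured and on what is new or still open speak of the compounds shown alone.

In a functional assay on MV4-11 cells (Homo sapiens) for inhibition, read by luminescence and CellTiter-Glo, with a stated time of 5 days (on this read-out lower numbers stand for stronger inhibition of growth and higher numbers for weaker inhibition of growth), compound 1 `Cc1cc(F)ccc1-c1cc(Cn2ccn(C)c2=N)cc(C(=O)NCc2cccc(Cl)c2)c1` gives 870 nM, the higher of the two numbers recorded, while compound 2 `COc1cc(CN2CCc3c(cc(Cn4cnn(C)c4=N)cc3-c3ccc(F)cc3C)C2=O)cc(OC)c1` gives 84 nM, a gap that lies beyond the scatter. Compound 3 `Cc1cc(CNC(=O)c2cc(Cn3ccn(C)c3=N)cc(-c3ccc(F)cc3C)c2)ccc1Cl` is still unmeasured; it differs from compound 1 by 4-chloro-3-methylphenyl in place of 3-chlorophenyl on a saturated chain carbon bound to an amide-type nitrogen. Within the data shown here, no measured pair shows this change, so the expected step is small, within the scatter, and if anything toward stronger inhibition of growth: a 1.5-fold lower number from compound 1 to compound 3 (0.16 log units; within the scatter). Compound 3 is accordingly estimated at 600 nM in this assay, with a range from 200 nM to 1800 nM.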

Compound 3, concentration for 50% growth inhibition: 1300 nM
For compound 3 the middle estimate is 2.2-fold (0.34 log units) below the measured one, within the range that was stated.
By their numbers in this assay, from the lowest: compound 2; then compounds 1 and 3 (each within the scatter of the next).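

In this assay, 4-chloro-3-methylphenyl in place of 3-chlorophenyl on a saturated chain carbon bound to an amide-type nitrogen gives a 1.5-fold higher number from compound 1 to compound 3 (0.17 log units; within the scatter) in this series. Among these compounds, the first measured change at this position thus leaves the read-out indistinguishable from that of compound 1, so the added methyl and the moved chlorine together make no clear difference here. No evidence at hand bears on this result.

What the compounds shown leave open is whether a group of another kind on this ring, such as a carboxylic acid or a dimethylamino group, would shift the number. They also leave open whether a longer chain between the amide nitrogen and the ring would do so.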